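Adding a Second Chloro to the Anilino Ring of Compound 3

The source may report more compounds than this note shows. Statements on the series, on what has been measured and on what is new or still open speak of the compounds shown alone.

Compound 3 `COc1cccc(/C=C/C(=O)c2sc(Nc3cccc(Cl)c3)nc2C)c1` carries a (3-chlorophenyl)amino group on the shared core. In a functional assay on PC-3 cells (Homo sapiens) for cytotoxicity, read by MTT assay (on this read-out higher numbers stand for weaker inhibition and lower numbers for stronger inhibition), compound 3 gives > 25000 nM, which is a limit of the assay and not a number. Its two companions fare no differently. Compound 1 `COc1cccc(/C=C/C(=O)c2sc(Nc3ccccc3)nc2C)c1` gives > 25000 nM in this assay, again a limit. Compound 2 `Cc1nc(Nc2ccc(Cl)c(Cl)c2)sc1C(=O)/C=C/c1ccc(Cl)cc1`, which already carries a (3,4-dichlorophenyl)amino group, gives > 25000 nM, likewise a limit. All three values sit at the limit of > 25000 nM in this assay, at which 3 of the 3 values shown sit, so compound 3 stands at the limit alongside the others, with no number to separate it from them.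

Compound 4 `COc1cccc(/C=C/C(=O)c2sc(Nc3ccc(Cl)c(Cl)c3)nc2C)c1` differs from compound 3 by chloro in place of hydrogen on an aromatic carbon. For the measured compounds named here, the one measured step of this kind, a step that the two limits leave unreadable from compound 1 to compound 3, has both ends at the limit and therefore shows neither size nor direction. Nothing in this set gives a readable size for the change from compound 3 to compound 4, and what is shown for compound 2, which shares the dichloro pattern, is once more a limit. The expectation is that the step that the limit leaves unreadable from compound 3 to compound 4 leaves compound 4 at the limit as well. Compound 4 is estimated at 40000 nM in this assay, with a range from 12000 nM to 150000 nM.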

Compound 4, half-maximal inhibitory concentration: 10100 nM
Compound 4: middle estimate off by 4.0-fold (0.60 log units), on the high side, outside the stated range (below it).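

With chloro in place of hydrogen on this aromatic carbon, ortho to a chloro group and para to a large group, the series gives an at least 2.4-fold lower number from compound 3 to compound 4 (0.39 log units; beyond the scatter), the first step whose direction can be read, since the earlier step from the single chloro could not be. The 3,4-dichlorophenyl group does not bring this about in every setting: compound 2 carries it too, and 3-methoxyphenyl in place of 4-chlorophenyl gives an at least 2.4-fold lower number from compound 2 to compound 4 (0.39 log units; beyond the scatter), while 3,4-dichlorophenyl in place of phenyl gives an at least 2.4-fold lower number from compound 1 to compound 4 (0.39 log units; beyond the scatter). Compound 4 is therefore the only compound shown that comes off the limit, so the two changes appear to matter together here: the limit of > 25000 nM in this assay, at which 3 of the 4 values shown sit.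

On these data alone, each of these steps starts from a limit, so its true size stays unknown, and a single measured compound cannot show how far the gain extends. The compounds shown also leave open whether a bromo or a trifluoromethyl group on this same carbon would serve as the second chloro does, and whether chloro here without the 3-chloro group would be enough.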